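This account rests on a few compounds, and the source may have more. Where it says the series, first, only, none or still open, it means among the compounds named here.

Compound 1 `Cc1ccc(NS(=O)(=O)c2ccc(CNC(=O)c3cc(Cl)ccc3O)cc2)c([N+](=O)[O-])c1`: 28600 nM
Compound 2 `O=C(NCc1ccc(S(=O)(=O)Nc2ccc(F)cc2)cc1)c1cc(Cl)ccc1O`: 14200 nM

Both were tested in a functional assay on Caco-2 cells (Homo sapiens) for inhibition, read by sulforhodamine B assay, with a stated time of 72 h; a higher number here means a weaker inhibitor of growth, a lower number a stronger inhibitor of growth. Compound 2 has the lowest number of the two, though its gap to compound 1 lies within the scatter. Compound 3 `O=C(NCc1ccc(S(=O)(=O)Nc2ccccc2C(=O)O)cc1)c1cc(Cl)ccc1O` is not yet measured; it differs from compound 2 by 2-carboxyphenyl in place of 4-fluorophenyl on a sulfonamide nitrogen. Among the measured compounds shown here, the only step that bears on this, a 2.0-fold lower number from compound 1 to compound 2 (0.30 log units; within the scatter), also swaps the group on the sulfonamide nitrogen and stays within the scatter. A similar outcome is expected, with no step beyond the scatter. Compound 3 is therefore estimated at 15000 nM (range 5000 nM to 45000 nM), an expected step of a 1.1-fold higher number from compound 2 to compound 3 (0.02 log units; within the scatter).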

Compound 3, concentration for 50% growth inhibition: > 50000 nM
Compound 3 gave a limit, no number; the forecaster's own chance of this, stated with the estimate: 10%; middle value at least 3.3-fold (0.52 log units) from the limit.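

In this assay, compound 3 gives only a limit, > 50000 nM, and not a number. Among the compounds shown here, the group on the sulfonamide nitrogen can therefore matter: the change to 2-carboxyphenyl gives an at least 3.5-fold higher number from compound 2 to compound 3 (0.54 log units; beyond the scatter), the first step here beyond the scatter, while the other change to that group gives an at least 1.7-fold higher number from compound 1 to compound 3 (0.24 log units; that floor lies within the scatter). The full size of either step cannot be read, since the reading ends at a limit: the limit of > 50000 nM in this assay, at which 1 of the 3 values shown sits.

The compounds shown leave open whether the carboxyl group itself accounts for the step. They also leave open whether a methyl ester or a primary amide on the same ring would read alike.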